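The source may report more compounds than this note shows. Statements on the series, on what has been measured and on what is new or still open speak of the compounds shown alone.

Measured compounds: compound 1 `CCOC(=O)/C=C/C(=O)N(CC(N)=O)NC(=O)[C@@H]1CCCN1C(C)=O`, 8.3 nM; compound 2 `CCOC(=O)/C=C/C(=O)N(CC(N)=O)NC(=O)[C@@H]1CCCN1C(=O)[C@H]1CSCN1C(C)=O`, 167 nM; compound 3 `C/C=C(\NC(C)=O)C(=O)N1CCC[C@H]1C(=O)NN(CC(N)=O)C(=O)/C=C/C(=O)OCC`, 141 nM; all in an assay on isolated protein for inhibition of legumain (Mus musculus), read by fluorescence, with stated times of 30 s and 2.5 h; on this read-out higher numbers stand for weaker inhibition and lower numbers for stronger inhibition.

Compound 3 stands second highest of the three numbers: its nearest neighbour is compound 2, with a 1.2-fold lower number from compound 2 to compound 3 (0.07 log units; within the scatter), while compound 1 lies furthest, with a 17-fold higher number from compound 1 to compound 3 (1.23 log units; beyond the scatter). Compound 4 `CCOC(=O)/C=C/C(=O)N(CC(N)=O)NC(=O)[C@@H]1CCCN1C(=O)c1ccc(CNC(C)=O)cc1` differs from compound 3 by a group of 11 heavy atoms (9 carbon, 1 nitrogen, 1 oxygen; one six-membered aromatic ring of carbon only) in place of a group of 7 heavy atoms (5 carbon, 1 nitrogen, 1 oxygen; no ring), on a carbonyl carbon. Among the measured compounds shown here, two steps bear on this change: a 20-fold higher number from compound 1 to compound 2 (1.30 log units; beyond the scatter) and a 17-fold higher number from compound 1 to compound 3 (1.23 log units; beyond the scatter), each a large rise when a bigger group replaces one carbon atom on that carbonyl carbon, whereas a 1.2-fold lower number from compound 2 to compound 3 (0.07 log units; within the scatter) shows that two such bigger groups give much the same number. For compound 4, another exchange of one bigger group for another, no step beyond the scatter is therefore expected, a 1.1-fold higher number from compound 3 to compound 4 (0.03 log units; within the scatter). Compound 4 is estimated at 150 nM, within 40 nM to 550 nM.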

Compound 4, half-maximal inhibitory concentration: 267 nM
Compound 4: the middle estimate sits 1.8-fold (0.25 log units) below what was measured, and the stated range covers the measured number.
By their numbers in this assay, from the lowest: compound 1; then compounds 3, 2 and 4 (each within the scatter of the next).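

In this assay, 4-(acetamidomethyl)phenyl in place of methyl on this carbonyl carbon gives a 32-fold higher number from compound 1 to compound 4 (1.51 log units; beyond the scatter), so a group with an aromatic ring also leaves compound 4 far from compound 1. Against the two other bigger groups, the result is a 1.9-fold higher number from compound 3 to compound 4 (0.28 log units; within the scatter) and a 1.6-fold higher number from compound 2 to compound 4 (0.20 log units; within the scatter), so the three bigger groups, with or without a ring, are not separated here. Nothing given here accounts for these steps. Still open, from the compounds shown here alone, is whether an ethyl group on this carbonyl carbon stays close to compound 1, and whether a plain phenyl or a 4-(aminomethyl)phenyl group behaves like 4-(acetamidomethyl)phenyl.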